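The compounds below may be only part of what the source reports. "The series", "measured", "known", "first", "only" and "open" are said of these compounds alone.

The series shares one core, seen in compound 1 `CCOc1cc(=O)n(CCCO)c2c1CC(CC=C(C)C)C(C)(C)C2`, compound 2 `CC(C)=CCC/C(C)=C/COc1cc(=O)n(CCCO)c2c1CC(CC=C(C)C)C(C)(C)C2` and compound 3 `CC(C)=CCC1Cc2c(OCCCNS(=O)(=O)c3ccc(C(F)(F)F)cc3)cc(=O)n(CCCO)c2CC1(C)C`. In a functional assay on PANC-1 cells (Homo sapiens) for inhibition, read by MTT assay, with a stated time of 24 h, tested at 10 uM (on this read-out lower numbers stand for less inhibition and higher numbers for more inhibition at the one concentration tested (going by the name of the read-out)), compound 1 gives 66.5%, while compound 2 gives 10.6%; the change a number 55.9 percentage points lower from compound 1 to compound 2 (beyond the scatter). Compound 3 gives 29.6% in this assay, which places it second highest of the three, nearer to compound 2 than to compound 1.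

Compound 4 `CC(C)=CCC1Cc2c(OCCCNS(=O)(=O)c3ccc(Br)cc3)cc(=O)n(CCCO)c2CC1(C)C` differs from compound 3 in one place: bromo in place of trifluoromethyl on an aromatic carbon. Going by the values given here, the only step measured so far, from compound 1 to compound 2, sits at the ether oxygen side chain and not at the aromatic ring of the sulfonamide, so no measured step speaks directly to this exchange. With nothing to draw on, the expectation is a step within the usual scatter: the estimated change is a number 0.4 percentage points higher from compound 3 to compound 4 (within the scatter). Compound 4 is therefore expected to give about 30% in this assay, within a range from 14% to 46%.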

Compound 4, a percentage reported as inhibition, at one concentration (the size of the read-out at that concentration, not a potency): 19.5%
Compound 4: middle estimate off by 10.5 percentage points, on the high side; measured number inside the range.
By their numbers in this assay, from the lowest: compounds 2 and 4 (each within the scatter of the next); then compound 3; then compound 1.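

In this assay the aromatic carbon of the sulfonamide ring proves to be a position that responds: bromo in place of trifluoromethyl gives a number 10.1 percentage points lower from compound 3 to compound 4 (beyond the scatter), a modest step and the first measured at this place. Going by these compounds alone, the chain carrying the 4-bromophenyl sulfonamide on the ether oxygen, taken against the ethyl ether of the core, gives a number 47 percentage points lower from compound 1 to compound 4 (beyond the scatter), so this second large side chain, like the one in compound 2, ends far under compound 1. No measurement offered here accounts for either step.

From the compounds shown here alone, it remains open whether a nitrile, a methoxy group or an amine on the same aromatic carbon would shift the number further. Going by these compounds, it also remains open whether a shorter chain on the ether oxygen, bearing the same sulfonamide, would recover any of the inhibition seen with compound 1.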